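Trimming the Dimethylamino Tail of Compound 3

The source may hold more compounds than are shown below. What is called first, only, known or untested is meant among the compounds shown, and "the series" means these compounds.

Three measured compounds share one core and differ only in the group on the sulfonyl sulfur. In an assay on CHO cells for displacement of a labelled ligand from prostaglandin D2 receptor 2 (Homo sapiens), read by scintillation counting (on this read-out higher numbers stand for weaker inhibition and lower numbers for stronger inhibition), compound 1 `Cc1ccc(S(=O)(=O)N2CCOCC2)cc1C#Cc1cc(Cl)ccc1OCC(=O)O` gives 3.6 nM, and compound 2 `CNS(=O)(=O)c1ccc(C)c(C#Cc2cc(Cl)ccc2OCC(=O)O)c1` gives 10 nM. Compound 3 `Cc1ccc(S(=O)(=O)N(C)CCCN(C)C)cc1C#Cc1cc(Cl)ccc1OCC(=O)O` gives 287 nM in this assay, the highest of the three numbers: the steps of an 80-fold higher number from compound 1 to compound 3 (1.90 log units; beyond the scatter) and a 29-fold higher number from compound 2 to compound 3 (1.46 log units; beyond the scatter) are both large and both beyond the scatter.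

Compound 4 `Cc1ccc(S(=O)(=O)N(C)CC(C)C)cc1C#Cc1cc(Cl)ccc1OCC(=O)O` differs from compound 3 in one place: isopropyl in place of 2-(dimethylamino)ethyl on a saturated chain carbon bound to a sulfonamide nitrogen. The step of a 29-fold higher number from compound 2 to compound 3 (1.46 log units; beyond the scatter) bears most directly on this change, since it added the whole 3-(dimethylamino)propyl chain to a sulfonamide nitrogen and cost a large amount; compound 4 keeps only the start of that chain and loses the dimethylamino end. A large move back toward the numbers of compound 2 and compound 1 is therefore expected, though not necessarily all the way. For compound 4 the expected step is a 14-fold lower number from compound 3 to compound 4 (1.16 log units; beyond the scatter). The estimate for compound 4 in this assay is 20 nM, with a range from 5 nM to 80 nM.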

Compound 4, inhibition constant: 4.2 nM
The estimate for compound 4 lay 4.8-fold (0.68 log units) above the measured number, and the stated range ends above it.
By their numbers in this assay, from the lowest: compounds 1 and 4 (each within the scatter of the next); then compound 2; then compound 3.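

Taking away the dimethylamino end and stopping at isobutyl removes nearly all of the loss seen with the longer chain in this assay (a 68-fold lower number from compound 3 to compound 4 (1.83 log units; beyond the scatter)). The loss therefore goes with that end of the chain and not with every carbon chain on the sulfonamide nitrogen, as the isobutyl group of compound 4 improves on the hydrogen of compound 2 by a modest step (a 2.4-fold lower number from compound 2 to compound 4 (0.38 log units; beyond the scatter)). The morpholin-4-yl ring is also not needed to reach the low numbers, as the open isobutyl(methyl)amino group reads the same within the scatter (a 1.2-fold higher number from compound 1 to compound 4 (0.07 log units; within the scatter)).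

Nothing shown here explains why the dimethylamino end is so costly. From the compounds shown here alone, it remains open whether a hydroxyl group or a methoxy group at the end of the chain would read like compound 4 or like compound 3.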